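This account rests on a few compounds, and the source may have more. Where it says the series, first, only, none or still open, it means among the compounds named here.

Compound 1 `COc1cc(C(C)=O)ccc1OCCCN1CCC(C(c2ccc(F)cc2)c2ccc(F)cc2)CC1` and compound 2 `Nc1ccc(OCCCN2CCC(C(c3ccc(F)cc3)c3ccc(F)cc3)CC2)cc1` share one core and differ only in the aryl group carried on the ether oxygen. In a functional assay (aorta) with Oryctolagus cuniculus as the target (a higher number here means weaker binding, a lower number tighter binding), compound 1 gives 1.59 nM, and compound 2 gives 31.6 nM, the highest of the two numbers obtained so far. Going by the values given here, the single measured step, a 20-fold higher number from compound 1 to compound 2 (1.30 log units; beyond the scatter), shows that this end of the molecule can move the number considerably. Compound 3 `Fc1ccc(C(c2ccc(F)cc2)C2CCN(CCCSc3ccccc3)CC2)cc1` carries the change (phenylsulfanyl in place of 4-aminophenoxy on a saturated chain carbon, three bonds along the chain from an amine nitrogen in a ring). Among the compounds with values here, no measured step bears directly on this exchange: from compound 1 to compound 2 one aryl group replaced another on the same oxygen, whereas here the aminophenyl part is lost and the linking atom itself is exchanged. Within the data shown here, the only guidance is that the aryl end is sensitive, without a direction for this particular change. A step of a 1.3-fold lower number from compound 2 to compound 3 (0.10 log units; within the scatter) is therefore expected, with wide uncertainty. Compound 3 is estimated at 25 nM, between 5 nM and 125 nM.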

Compound 3, dissociation constant: 3.16 nM
Compound 3: middle estimate off by 7.9-fold (0.90 log units), on the high side, and the stated range ends above it.
By their numbers in this assay, from the lowest: compounds 1 and 3 (each within the scatter of the next); then compound 2.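

Phenylsulfanyl in place of 4-aminophenoxy gives a 10-fold lower number from compound 2 to compound 3 (1.00 log units; beyond the scatter) in this assay and thus shows that this end of the molecule can also move the number downward from compound 2. The unsubstituted phenylsulfanyl end and the 4-acetyl-2-methoxyphenoxy end show a 2.0-fold higher number from compound 1 to compound 3 (0.30 log units; within the scatter) in this assay and so stand level, which means the acetyl and methoxy groups are not required for a number in this range among the compounds shown. Nothing available explains either step.

The step from compound 2 to compound 3 changes both the linking atom and the amine on the ring, so it leaves open which of the two accounts for the shift. A plain phenoxy group at the same place would separate these two changes, while a longer chain would test the spacing to the ring nitrogen.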